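The source may hold more compounds than are shown below. What is called first, only, known or untested is meant among the compounds shown, and "the series" means these compounds.

Measured compounds:
compound 1 `COc1ccccc1N1CCN(CCCNC(=O)NN(Cc2ccccc2F)c2ccc(F)cc2)CC1`: 3.6 nM
compound 2 `COc1ccccc1N1CCN(CCCNC(=O)NN(Cc2ccc(C#N)cc2)c2ccc(F)cc2)CC1`: 15 nM
compound 3 `COc1ccccc1N1CCN(CCCNC(=O)NN(Cc2ccc(-c3ccccc3)cc2)c2ccc(F)cc2)CC1`: 5.9 nM

In an assay on CHO cells for displacement of a labelled ligand from D(4) dopamine receptor (Homo sapiens), read by radioligand binding (a lower number here means a stronger inhibitor, a higher number a weaker inhibitor), compound 1 holds the lowest number of the three. Compound 3 stands nearest, a 1.6-fold higher number from compound 1 to compound 3 (0.21 log units; within the scatter), and compound 2 furthest, a 4.2-fold higher number from compound 1 to compound 2 (0.62 log units; beyond the scatter). Between the two larger groups the remaining step is a 2.5-fold lower number from compound 2 to compound 3 (0.41 log units; beyond the scatter).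

Compound 4 `COc1ccccc1N1CCN(CCCNC(=O)NN(Cc2ccccc2F)c2ccc(Cl)cc2)CC1` differs from compound 1 by chloro in place of fluoro on an aromatic carbon. Among the measured compounds shown here, every measured step alters the group on the saturated chain carbon, not the ring that carries the fluoro, so no measured step bears directly on this change; the shared core is otherwise untouched. A step within the scatter, in no firm direction, is expected for compound 4, a 1.1-fold higher number from compound 1 to compound 4 (0.05 log units; within the scatter). Compound 4 is estimated at 4 nM, range 1.5 nM to 12 nM.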

Compound 4, inhibition constant: 2.6 nM
The estimate for compound 4 lay 1.5-fold (0.19 log units) above the measured number, and the stated range covers the measured number.
By their numbers in this assay, from the lowest: compounds 4, 1 and 3 (each within the scatter of the next, the first and the last beyond it); then compound 2.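

Among the compounds shown here, the halogen-bearing ring was not varied in the earlier steps, which all altered the group on the saturated chain carbon. In this assay the change from 4-fluorophenyl to 4-chlorophenyl gives a 1.4-fold lower number from compound 1 to compound 4 (0.14 log units; within the scatter) and stays within the scatter, so at this position chloro and fluoro are not told apart. No evidence on the cause of this result is available.

As far as these compounds go, whether a non-halogen group at this position, such as methoxy or an amine, would hold the number remains open. So does whether chloro reads the same with 4-cyanophenyl or 4-phenylphenyl on the chain carbon.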